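Working notes: from compound 2 to compound 3

The compounds below may be only part of what the source reports. "The series", "measured", "known", "first", "only" and "open" are said of these compounds alone.

The series shares one core, seen in compound 1 `C=CCOC1=CC(=O)S[C@]1(C)CCCCCC`, compound 2 `CCCCCC[C@@]1(C)SC(=O)C=C1OCC(=O)NCC(=O)OC` and compound 3 `CCCCCC[C@@]1(C)SC(=O)C=C1OCC(=O)NCCCBr`. In a functional assay on MCF7 cells (Homo sapiens) for inhibition (on this read-out lower numbers stand for stronger inhibition and higher numbers for weaker inhibition), compound 1 gives > 50 ug/mL, which is a limit of the assay and not a number.

In this assay, among the compounds with values here, compound 2 gives 9.8 ug/mL, the only actual number so far, so its standing cannot yet be expressed as a measured step.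

Compound 3 has not yet been measured. It carries 2-bromoethyl in place of methoxycarbonyl on a saturated chain carbon bound to an amide-type nitrogen. Cut one bond further out, the same difference reads (methoxycarbonyl)methyl to 3-bromopropyl. Within the data shown here, no measured step bears on this change, so the expectation rests on compound 2 alone, at 9.8 ug/mL.

In this assay a small shift toward weaker inhibition is expected, not clearly beyond the usual scatter. The estimated step is a 1.4-fold higher number from compound 2 to compound 3 (0.15 log units; within the scatter). For compound 3 the expected value is 14 ug/mL, with an estimated range of 5 ug/mL to 40 ug/mL.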

Compound 3, half-maximal inhibitory concentration: 6.7 ug/mL
For compound 3 the middle estimate is 2.1-fold (0.32 log units) above the measured one, and the stated range covers the measured number.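

In this assay, exchanging methoxycarbonyl for 2-bromoethyl on a saturated chain carbon bound to an amide-type nitrogen gives a 1.5-fold lower number from compound 2 to compound 3 (0.17 log units; within the scatter), so compound 2 and compound 3 cannot be ordered, and methoxycarbonyl is not required at this position for a measurable value. Across the larger change, (3-bromopropyl)carbamoyl in place of vinyl on a saturated chain carbon bound to an oxygen on an unsaturated carbon gives an at least 7.4-fold lower number from compound 1 to compound 3 (0.87 log units; beyond the scatter), which shows a separation beyond the scatter for a second amide-bearing side chain, not for compound 2 alone. The true size of this step stays unknown, since compound 1 is represented by a limit of the assay and not by a number: the limit of > 50 ug/mL in this assay, at which 1 of the 3 values shown sits.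

Still open, as far as these compounds go, is whether a carboxylic acid in place of methoxycarbonyl, or an amine in place of the bromine, would stay level with compound 2 and compound 3. From the compounds shown here alone, it is also open whether the bromine matters at all, which a plain propyl chain on the same nitrogen would test, and how a longer chain would read out.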